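The compounds below may be only part of what the source reports. "The series", "measured", "known", "first", "only" and "open" are said of these compounds alone.

In a functional assay on MKN-74 cells (Homo sapiens) for antiproliferative activity, with a stated time of 24 h (a lower number here means a stronger inhibitor, a higher number a weaker inhibitor), three compounds sharing one core have been tested. Compound 1 `NC(=O)c1c(NC(=O)c2ccccc2Cl)sc2c1CCN(Cc1ccc(Cl)cc1Cl)C2` gives 16300 nM as its half-maximal inhibitory concentration. Compound 2 `NC(=O)c1c(NC(=O)c2ccc(C(F)(F)F)cc2)sc2c1CCN(Cc1ccc(Cl)cc1)C2` reads > 50000 nM and that is a limit of the assay, not a number. Going by the values given here, compound 3 `NC(=O)c1c(NC(=O)c2ccc(C(F)(F)F)cc2)sc2c1CCN(Cc1c(Cl)cccc1Cl)C2` gives 8530 nM and so stands within the usual scatter of compound 1, the only other true number so far. Compound 4 `NC(=O)c1c(NC(=O)c2ccc(C(F)(F)F)cc2)sc2c1CCN(Cc1ccc(Cl)cc1Cl)C2` differs from compound 3 at a single place (2,4-dichlorophenyl in place of 2,6-dichlorophenyl on a saturated chain carbon bound to an amine nitrogen in a ring), with 2,4-dichlorophenyl in place of 2,6-dichlorophenyl on a saturated chain carbon bound to an amine nitrogen in a ring. Among the compounds with values here, one measured step touches this place, an at least 5.8-fold lower number from compound 2 to compound 3 (0.76 log units; beyond the scatter) and it shows that changing this group can move the number beyond the scatter. Compound 1 carries the 2,4-dichlorophenyl group too, alongside a different group elsewhere, and gives 16300 nM as a true number. The estimated 1.8-fold higher number from compound 3 to compound 4 (0.25 log units; within the scatter) is therefore a small one toward a higher number, expected to stay near the scatter. Compound 4 is estimated at 15000 nM with a range of 5000 nM to 45000 nM expected.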

Compound 4, half-maximal inhibitory concentration: 10900 nM
For compound 4 the middle estimate is 1.4-fold (0.14 log units) above the measured one; the measured number falls inside the stated range.
By their numbers in this assay, from the lowest: compounds 3, 4 and 1 (each within the scatter of the next). At a limit, above all of these: compound 2.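

With the chlorines arranged differently, this assay shows a 1.3-fold higher number from compound 3 to compound 4 (0.11 log units; within the scatter), and 4-(trifluoromethyl)phenyl in place of 2-chlorophenyl on a carbonyl carbon gives a 1.5-fold lower number from compound 1 to compound 4 (0.17 log units; within the scatter), so neither change can be told from the scatter. The clearer change is chloro in place of hydrogen on an aromatic carbon, which gives an at least 4.5-fold lower number from compound 2 to compound 4 (0.66 log units; beyond the scatter), so both dichlorophenyl compounds now stand apart from the compound with a single chlorine. The reading for compound 2 is a limit of the assay, not a number: the limit of > 50000 nM in this assay, at which 1 of the 4 values shown sits.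

As far as these compounds go, it remains open whether the second chlorine itself matters, or whether a methyl, a methoxy or a nitrile on the same ring would serve equally well. From the compounds shown here alone, it is also open whether a group other than a substituted benzyl, such as a longer chain ending in an amine, would keep these numbers on the shared core.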